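The source may hold more compounds than are shown below. What is called first, only, known or untested is meant among the compounds shown, and "the series" means these compounds.

Measured in an ADME assay on BaF3 cells (Mus musculus) for cytotoxicity, read by MTT assay, with a stated time of 48 h; a higher number here means a weaker inhibitor of growth, a lower number a stronger inhibitor of growth:
- Compound 1 `CC(C)n1nc(-c2cc(C3CCCCC3)on2)c2c(N)ncnc21`: > 10000 nM, a limit
- Compound 2 `Nc1ncnc2c1c(-c1cc(C3CC3)on1)nn2C1CCCCC1`: > 10000 nM, a limit
- Compound 3 `CC(C)(O)Cn1nc(-c2cc(C3CC3)on2)c2c(N)ncnc21`: > 10000 nM, a limit

Compound 1 offers no exact number to start from, only (the limit of > 10000 nM in this assay, at which 3 of the 3 values shown sit).

Compound 4 `CC(C)c1cc(-c2nn(C(C)C)c3ncnc(N)c23)no1` keeps the core of compound 1 and has isopropyl in place of cyclohexyl on an aromatic carbon.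

Within the data shown here, the one measured step, a step that the two limits leave unreadable from compound 2 to compound 3, lies at a different place and has no readable size. Among the measured compounds shown here, no measured step therefore sets a size for this change in this assay, and the estimated step that the limit leaves unreadable from compound 1 to compound 4 is expected to have no clear direction. Compound 4 is expected at about 15000 nM, with an estimated range of 6000 nM to 40000 nM, and will most likely be reported as a limit too.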

Compound 4, concentration for 50% growth inhibition: > 10000 nM
Compound 4: no number, only a limit; the forecaster's own chance of this, stated with the estimate: 85%; the middle value lies beyond the limit too.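

Among these compounds, compound 4, like compound 1, gives only a limit and no exact number, so no step between them can be read: the limit of > 10000 nM in this assay, at which 4 of the 4 values shown sit.

The compounds shown leave open whether isopropyl in place of cyclohexyl changes growth inhibition at all, and how strongly any of them inhibits growth.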